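Chain growth on the aryl urea: compound 2 to compound 3

A few compounds are considered here, and "the series" means these few. Any claim that something is new, unique, unknown or untested is made for them only; others in the source may bear on it.

Compound 2 `CCCc1ccc(NC(=O)N[C@H](C)c2ccccc2)cc1` gives the lowest of the two numbers in an ADME assay on the whole organism with Oryza sativa as the target, tested at 0.1 uM (on this read-out higher numbers stand for a weaker effect at the one concentration tested and lower numbers for a stronger effect), at 33%; compound 1 `Cc1ccc(NC(=O)N[C@H](C)c2ccccc2)cc1` sits higher at 100%. Among the measured compounds shown here, the only measured step, a number 67 percentage points lower from compound 1 to compound 2 (beyond the scatter), came with ethyl in place of hydrogen on a saturated chain carbon bound to an aromatic carbon. Compound 3 `C[C@@H](NC(=O)Nc1ccc(C(C)(C)C)cc1)c1ccccc1` carries tert-butyl in place of propyl on an aromatic carbon. For the measured compounds named here, no measured step covers this exchange, so the expectation rests loosely on that one step and on the similar size of the two groups, with an expected step of a number 2 percentage points higher from compound 2 to compound 3 (within the scatter). Compound 3 is expected to give 35%, within 10% to 70%.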

Compound 3, a percentage reported as activity, at one concentration (the size of the read-out at that concentration, not a potency): 100%
For compound 3 the middle estimate is 65 percentage points below the measured one; measured number outside the range, above it.
By their numbers in this assay, from the lowest: compound 2; then compounds 1 and 3 (each within the scatter of the next).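

Propyl and tert-butyl are not interchangeable on this aromatic carbon in this assay: the exchange gives a number 67 percentage points higher from compound 2 to compound 3 (beyond the scatter), so the stronger effect seen with propyl does not carry over to tert-butyl. Replacing methyl with tert-butyl gives no change at the digits printed from compound 1 to compound 3 (within the scatter), which leaves compound 2 alone apart from the other two compounds. No available evidence accounts for this difference. As far as these compounds go, it remains open whether the effect depends on an unbranched chain, and whether ethyl, butyl or pentyl would follow propyl. An isopropyl group on the same carbon would also show whether branching alone matches tert-butyl.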